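A few compounds are considered here, and "the series" means these few. Any claim that something is new, unique, unknown or untested is made for them only; others in the source may bear on it.

Compounds measured so far in a functional assay on HCC1937 cells (Homo sapiens) for antiproliferative activity, read by CCK-8 assay, with a stated time of 72 h; on this read-out lower numbers stand for stronger inhibition and higher numbers for weaker inhibition:

compound 1 `O=C(Nc1cccc(-c2oc3cc(-c4ccc(F)cc4)ccc3c(=O)c2O)c1)c1ccccc1F` — 10800 nM
compound 2 `O=C(Nc1cccc(-c2oc3cc(-c4ccc(F)cc4)ccc3c(=O)c2O)c1)c1cccc(F)c1` — 6590 nM
compound 3 `Cc1cc(C)cc(C(=O)Nc2cccc(-c3oc4cc(-c5ccc(F)cc5)ccc4c(=O)c3O)c2)c1` — 4860 nM

Among the measured compounds shown here, compound 3 gives the lowest of the three numbers in this assay, though only one of its two steps clears the scatter: there is a 1.4-fold lower number from compound 2 to compound 3 (0.13 log units; within the scatter), and there is a 2.2-fold lower number from compound 1 to compound 3 (0.35 log units; beyond the scatter).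

Compound 4 `N#Cc1ccc(C(=O)Nc2cccc(-c3oc4cc(-c5ccc(F)cc5)ccc4c(=O)c3O)c2)cc1` differs from compound 3 in one place: 4-cyanophenyl in place of 3,5-dimethylphenyl on a carbonyl carbon. All three measured steps exchange the aryl group on this same carbonyl carbon and therefore bear on the change: a 1.6-fold lower number from compound 1 to compound 2 (0.21 log units; within the scatter), a 2.2-fold lower number from compound 1 to compound 3 (0.35 log units; beyond the scatter) and a 1.4-fold lower number from compound 2 to compound 3 (0.13 log units; within the scatter). Across those exchanges the whole series spans barely more than the scatter, and no measured compound carries a nitrile on this ring, so the new group itself is untested. On this evidence the step is expected to stay small in this assay, most likely a 1.3-fold higher number from compound 3 to compound 4 (0.13 log units; within the scatter), with no direction established beyond the scatter. Compound 4 is accordingly estimated at 6500 nM, within a range of 2500 nM to 17000 nM.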

Compound 4, half-maximal inhibitory concentration: 2990 nM
The estimate for compound 4 lay 2.2-fold (0.34 log units) above the measured number, within the range that was stated.
By their numbers in this assay, from the lowest: compounds 4, 3, 2 and 1 (each within the scatter of the next, the first and the last beyond it).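

In this assay, 4-cyanophenyl in place of 3,5-dimethylphenyl on the carbonyl carbon gives a 1.6-fold lower number from compound 3 to compound 4 (0.21 log units; within the scatter), so a nitrile on this aryl ring is tolerated without a separation from the dimethyl-substituted ring. Against the fluorinated aryl groups the same group does clear the scatter, with a 2.2-fold lower number from compound 2 to compound 4 (0.34 log units; beyond the scatter) and a 3.6-fold lower number from compound 1 to compound 4 (0.56 log units; beyond the scatter), which widens the span seen at this position beyond that of the earlier compounds. No measurement at hand accounts for these differences.

Open, on these data alone, is whether the nitrile itself drives the separation from the fluorinated rings, as these aryl groups differ in both the kind and the number of their substituents. Also open is whether a carboxylic acid, an amine or a saturated ring such as cyclohexyl on this carbonyl carbon would move the number further than any aryl group shown here.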